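Extending the enaminone core of compound 3 with a hydroxyethyl dithioester

The compounds below may be only part of what the source reports. "The series", "measured", "known", "first", "only" and "open" are said of these compounds alone.

The account concerns two analogues sharing a dimethyl cyclohexenone core. Compound 1, `CC1(C)CC(=O)C=C(Nc2ccc(Cl)cc2Cl)C1`, gives 17.6 ug/mL in a functional assay on PBMC cells (Homo sapiens) for inhibition, read by thymidine incorporation, with a stated time of 72 h; on this read-out lower numbers stand for stronger inhibition and higher numbers for weaker inhibition. Compound 3, `CC1(C)CC(=O)C=C(Nc2ccc(Cl)cc2)C1`, gives 15 ug/mL in this assay, the lowest of the two numbers shown, though its neighbour compound 1 sits within the scatter: the step of a 1.2-fold lower number from compound 1 to compound 3 (0.07 log units; within the scatter) carries no weight of its own. Compound 2, `CCCCCCCCCCCSC(=S)C1=C(Nc2ccc(Cl)cc2Cl)CC(C)(C)CC1=O`, reaches only the limit > 50 ug/mL in this assay, which is a limit of the assay and not a number. Compound 4, `CC1(C)CC(=O)C(C(=S)SCCO)=C(Nc2ccc(Cl)cc2)C1`, is not yet measured. It differs from compound 3 by a group of 6 heavy atoms (3 carbon, 1 oxygen, 2 sulfur; no ring) in place of a hydrogen atom, on a double-bonded ring carbon. For the measured compounds named here, no measured single step covers this change. Going by the values given here, the only pointer is compound 2, whose long-chain dithioester on the same ring position sits at the limit of > 50 ug/mL in this assay, at which 1 of the 3 values shown sits, while compound 1 gives a number. A weaker outcome for compound 4 than for compound 3 is therefore expected, by a 2.0-fold higher number from compound 3 to compound 4 (0.30 log units; within the scatter), and its value in this assay is estimated at 30 ug/mL, between 12 ug/mL and 75 ug/mL.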

Compound 4, half-maximal inhibitory concentration: 21 ug/mL
Beside the measured number, compound 4's estimate is 1.4-fold (0.15 log units) above it; measured number inside the range.
By their numbers in this assay, from the lowest: compounds 3, 1 and 4 (each within the scatter of the next). At a limit, above all of these: compound 2.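

In this assay, putting a group of 6 heavy atoms on the double-bonded ring carbon in place of a hydrogen atom gives a 1.4-fold higher number from compound 3 to compound 4 (0.15 log units; within the scatter). The change therefore leaves the read-out within the scatter and still yields a number, so a dithioester on this ring carbon does not in itself end at a limit. Until now, the only compound shown with a group on this carbon was compound 2, whose value is a limit and not a number: the limit of > 50 ug/mL in this assay, at which 1 of the 4 values shown sits.

Compound 2 and compound 4 differ in more than one place, so the compounds shown do not tell whether the long chain or the second ring chloro goes with that limit. Also open, going by these compounds, is how a dithioester chain carrying an amine or a carboxylic acid instead of the hydroxy group would read in this assay.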